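Chain replacement at the aromatic nitrogen: outlook for compound 4

The source may report more compounds than this note shows. Statements on the series, on what has been measured and on what is new or still open speak of the compounds shown alone.

Measured compounds:
compound 1 `COc1ccc(F)cc1-c1cccc(-c2nn(CCCC#N)c(=O)o2)c1`, 85%
compound 2 `COc1ccc(F)cc1-c1cccc(-c2n[nH]c(=O)o2)c1`, 71%
compound 3 `COc1ccc(F)cc1-c1cccc(-c2nn(CCCCF)c(=O)o2)c1`, 95%

In a functional assay on the whole organism (strain Wistar albino) for inhibition, with Rattus norvegicus as the target, read by paw edema, with stated times of 30 min and 3 h, at a dose of 10 mg/kg by the oral route (on this read-out higher numbers stand for more inhibition at the one dose given (going by the name of the read-out) and lower numbers for less inhibition), compound 3 stands highest of the three numbers; compound 1 sits within the scatter of it (a number 10 percentage points higher from compound 1 to compound 3 (within the scatter)), while compound 2 lies beyond it (a number 24 percentage points higher from compound 2 to compound 3 (beyond the scatter)). Compound 4 `COc1ccc(F)cc1-c1cccc(-c2nn(CCOC3CCCCO3)c(=O)o2)c1` differs from compound 3 in one place: (oxan-2-yl)oxy in place of 2-fluoroethyl on a saturated chain carbon, two bonds along the chain from an aromatic nitrogen. Among the compounds with values here, the steps that bear on this are the swap at the chain end, a number 10 percentage points higher from compound 1 to compound 3 (within the scatter), and the removal of the whole chain, a number 14 percentage points lower from compound 1 to compound 2 (beyond the scatter). Compound 4 keeps a chain on the aromatic nitrogen, so no step beyond the scatter is expected; the estimated step of a number 9 percentage points lower from compound 3 to compound 4 (within the scatter) is small and slightly downward. For compound 4 the estimate in this assay is 86%, range 70% to 97%.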

Compound 4, a percentage reported as inhibition, in the whole organism at one dose (the size of the read-out at that dose, not a potency): 65%
Compound 4: the middle estimate sits 21 percentage points above what was measured; measured number outside the range, below it.
By their numbers in this assay, from the lowest: compounds 4 and 2 (each within the scatter of the next); then compounds 1 and 3 (each within the scatter of the next).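

In this assay a chain on the aromatic nitrogen does not by itself hold the number: the 2-((oxan-2-yl)oxy)ethyl chain falls away from the 4-fluorobutyl chain (a number 30 percentage points lower from compound 3 to compound 4 (beyond the scatter)) and from the 3-cyanopropyl chain (a number 20 percentage points lower from compound 1 to compound 4 (beyond the scatter)). Set against the bare hydrogen, it gives no step beyond the scatter (a number 6 percentage points lower from compound 2 to compound 4 (within the scatter)), so the chain end matters at this position in a way the earlier compounds did not show. Nothing available explains this step.

Still open, on these data alone, is whether a plain 2-methoxyethyl chain behaves like the 2-((oxan-2-yl)oxy)ethyl chain. Also open, as far as these compounds go, is how an amine or a carboxylic acid at the chain end would read.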